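Replacing the amino alcohol with a hydroxy oxane on the alkyne

A few compounds are considered here, and "the series" means these few. Any claim that something is new, unique, unknown or untested is made for them only; others in the source may bear on it.

The study concerns a shared core bearing a fluorine, first seen in compound 1 `COc1cc[nH]c1/C=C1/C(=O)Nc2ccc(F)cc21`. In a functional assay on MDA-MB-435 cells (Homo sapiens) for inhibition (a lower number here means a stronger inhibitor, a higher number a weaker inhibitor), compound 1 reaches only the limit of the assay, > 30000 nM, and this limit of > 30000 nM in this assay, at which 1 of the 3 values shown sits, is the one clear fact about the unsubstituted core. Compound 2 `COc1cc[nH]c1/C=C1\C(=O)Nc2ccc(F)c(C#C[C@@H](C)O)c21` carries a 1-hydroxyethyl group on a triple-bonded carbon and gives 110 nM in this assay. Compound 3 `COc1cc[nH]c1/C=C1\C(=O)Nc2ccc(F)c(C#C[C@@H](N)CO)c21` gives 300 nM, which is the highest of the two numbers shown; the step of a 2.7-fold higher number from compound 2 to compound 3 (0.44 log units; beyond the scatter) is modest but beyond the scatter. Compound 4 `COc1cc[nH]c1/C=C1\C(=O)Nc2ccc(F)c(C#CC3(O)CCOCC3)c21` is not yet measured. It differs from compound 3 by 4-hydroxyoxan-4-yl in place of 1-amino-2-hydroxyethyl on a triple-bonded carbon. Within the data shown here, the only measured step that bears on this position is a 2.7-fold higher number from compound 2 to compound 3 (0.44 log units; beyond the scatter), showing that the group on the triple-bonded carbon shifts the number modestly. A tertiary alcohol on a ring resembles the hydroxyl of compound 2 more than the amino alcohol of compound 3, so a modest fall, a 2.0-fold lower number from compound 3 to compound 4 (0.30 log units; within the scatter), is expected. Compound 4 is therefore estimated at 150 nM, within 50 nM to 500 nM.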

Compound 4, half-maximal inhibitory concentration: 600 nM
Compound 4: middle estimate off by 4.0-fold (0.60 log units), on the low side, outside the stated range (above it).
By their numbers in this assay, from the lowest: compound 2; then compounds 3 and 4 (each within the scatter of the next). At a limit, above all of these: compound 1.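

In this assay, putting 4-hydroxyoxan-4-yl in place of 1-amino-2-hydroxyethyl on a triple-bonded carbon gives a 2.0-fold higher number from compound 3 to compound 4 (0.30 log units; within the scatter), so these two groups cannot be told apart at this position, although one carries nitrogen and an open chain and the other a six-membered ring and no nitrogen. Set against 1-hydroxyethyl, the same group gives a 5.5-fold higher number from compound 2 to compound 4 (0.74 log units; beyond the scatter), which leaves 1-hydroxyethyl as the only group here with a number clearly lower than both others. Nothing measured here accounts for these steps.

The compounds shown leave open how an open-chain 2-hydroxypropan-2-yl group or a 1-hydroxycyclohexyl ring, which has no ring oxygen, would read in this assay. Those two groups would show whether the ring itself or its oxygen goes with the higher number of compound 4.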